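The source may hold more compounds than are shown below. What is called first, only, known or untested is meant among the compounds shown, and "the series" means these compounds.

Of the compounds shown here, three built on one shared core have been tested in a functional assay on HCT-116 cells (Homo sapiens) for cytotoxicity, read by MTT assay, with a stated time of 72 h; on this read-out lower numbers stand for stronger inhibition and higher numbers for weaker inhibition. Compound 1 `Cc1c(/N=C/c2ccccc2Cl)c(=O)n(-c2ccccc2)n1C` gives 851000000 nM, the highest of the three numbers. Compound 3 `Cc1c(/N=C/c2ccccc2)c(=O)n(-c2ccccc2)n1C` gives 589000000 nM, and compound 2 `COc1ccc(/C=N/c2c(C)n(C)n(-c3ccccc3)c2=O)cc1OC` gives 575000000 nM; both lie within the usual scatter of compound 1, so no order among the three can be claimed from these numbers.

The unmeasured compound 4 `Cc1c(/N=C/c2cccc(Cl)c2)c(=O)n(-c2ccccc2)n1C` differs from compound 1 by 3-chlorophenyl in place of 2-chlorophenyl on a carbon with a double bond to nitrogen. Going by the values given here, the only measured step that touches the same part of the structure is a 1.4-fold lower number from compound 1 to compound 3 (0.16 log units; within the scatter), where the chloro was removed altogether rather than moved. Among the compounds with values here, nothing measured shows what moving a chloro within this ring does here, and no step among the three compounds reaches beyond the scatter, so there is no measured ground for expecting a change in either direction. The expected step is therefore roughly a 1.1-fold lower number from compound 1 to compound 4 (0.05 log units; within the scatter) in this assay, meaning no change beyond the scatter. For compound 4 the estimated value in this assay is 750000000 nM, with a range from 300000000 nM to 1800000000 nM.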

Compound 4, half-maximal inhibitory concentration: 912000000 nM
For compound 4 the middle estimate is 1.2-fold (0.08 log units) below the measured one; the measured number falls inside the stated range.
By their numbers in this assay, from the lowest: compounds 2, 3, 1 and 4 (each within the scatter of the next).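

In this assay, going by these compounds alone, a 1.1-fold higher number from compound 1 to compound 4 (0.03 log units; within the scatter) gives the first direct look at moving the chloro rather than removing it: 3-chlorophenyl in place of 2-chlorophenyl, on a carbon with a double bond to nitrogen, changes the number no more than repeated measurements would. Adding the chloro at this new place to the unsubstituted ring gives a 1.5-fold higher number from compound 3 to compound 4 (0.19 log units; within the scatter), and this is also within the scatter, so in this small set neither placement of the chloro can be told apart from having no chloro at all. No measurement at hand offers an explanation for how closely these compounds agree.

The compounds shown leave open whether a different kind of group on this ring, such as an amine or a carboxylic acid, would shift the number beyond the scatter. They also leave open whether changes elsewhere on the shared core, such as a longer chain in place of one of its methyl groups, would matter more than the place of a chloro.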